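The source may hold more compounds than are shown below. What is called first, only, known or untested is meant among the compounds shown, and "the series" means these compounds.

Working notes on a series sharing a core with a carboxylic acid and a 3,5-dichlorophenyl group on the pyrazole part, and an isopropylsulfanyl group on the thiazole part. Going by the values given here, in a functional assay on BJAB cells (Homo sapiens) for antiproliferative activity, with a stated time of 4 days (on this read-out lower numbers stand for an effect already at smaller amounts and higher numbers for an effect only at larger amounts of compound), compound 2 `Cc1c(-c2cc(Cl)cc(Cl)c2)c(C(=O)O)nn1-c1nc(-c2cc(Cl)cc(Cl)c2)c(SC(C)C)s1` gives 2000 nM, the only number so far in this assay. Among the compounds with values here, compound 1 `Cc1c(-c2cc(Cl)cc(Cl)c2)c(C(=O)O)nn1-c1nc(-c2cnn(C)c2)c(SC(C)C)s1` is reported in this assay as "not active" (no number reported), with no number attached; what the two entries show is that compound 2 carries the sole measurable value and compound 1 does not.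

Compound 3 `Cc1c(-c2cc(Cl)cc(Cl)c2)c(C(=O)O)nn1-c1nc(-c2ccc3nccn3c2)c(SC(C)C)s1` is the next candidate. It differs from compound 2 in one place: a group of 9 heavy atoms (7 carbon, 2 nitrogen; one five-membered aromatic ring with 2 hetero atoms, one six-membered aromatic ring with 1 hetero atom) in place of a group of 8 heavy atoms (6 carbon, 2 chlorine; one six-membered aromatic ring of carbon only), on an aromatic carbon. Within the data shown here, no measured pair isolates a change of this kind, so the direction of the step is open. Among the measured compounds shown here, the only guidance is that compound 1, which also carries a nitrogen-containing ring at this position, is reported as "not active" (no number reported), which points toward a loss rather than a gain.

The expected step is a 3.0-fold higher number from compound 2 to compound 3 (0.48 log units; beyond the scatter). For compound 3 the estimate is 6000 nM, with a range from 2000 nM to 20000 nM, and a fair chance that only a limit is reported.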

Compound 3, half-maximal effective concentration: "not active" (no number reported)
Nothing numeric was reported for compound 3, so the estimate cannot be set against anything.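

Going by these compounds alone, compound 3 carries no number in this assay, so no step from compound 2 to compound 3 can be read. Nothing measured here bears on this result. The compounds shown leave open whether any group other than 3,5-dichlorophenyl at this place gives a measurable value, and how such a value would compare with that of compound 2.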